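The source may hold more compounds than are shown below. What is called first, only, known or untested is meant among the compounds shown, and "the series" means these compounds.

Measured compounds:
Compound 1, `CCCCCOC(=O)N1CCN(C(=O)c2nc(Nc3cc(C4CC4)[nH]n3)c3cc(Cl)ccc3n2)C[C@H]1C`, 12.6%
Compound 2, `CC(OC(=O)C(C)C)OC(=O)N1CCN(C(=O)c2nc(Nc3cc(C4CC4)[nH]n3)c3cc(Cl)ccc3n2)C[C@H]1C`, 25.8%
Compound 3, `C[C@@H]1CN(C(=O)c2nc(Nc3cc(C4CC4)[nH]n3)c3cc(Cl)ccc3n2)CCN1C(=O)OCC(Cl)(Cl)Cl`, 63%

These three numbers come from an assay for inhibition of serine/threonine-protein kinase PAK 4 (Homo sapiens), read by FRET and Z'-LYTE, with a stated time of 60 min, tested at 5 uM, in the presence of a further agent that is not named here; on this read-out higher numbers stand for a stronger effect at the one concentration tested and lower numbers for a weaker effect. Compound 3 stands highest of the three, clear of compound 2 and further still from compound 1. The unmeasured compound 4 is `CCOC(=O)N1CCN(C(=O)c2nc(Nc3cc(C4CC4)[nH]n3)c3cc(Cl)ccc3n2)C[C@H]1C`; it differs from compound 3 by methyl in place of trichloromethyl on a saturated chain carbon bound to an oxygen next to a carbonyl group.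

For the measured compounds named here, two measured steps bear on this change. The step of a number 50.4 percentage points higher from compound 1 to compound 3 (beyond the scatter) is the closest analogue, since it exchanges one saturated chain carbon substituent for trichloromethyl at the same place, and the step from compound 3 to compound 4 reverses that kind of exchange, trichloromethyl leaving and methyl entering. The step of a number 37.2 percentage points higher from compound 2 to compound 3 (beyond the scatter) points the same way, with a different group on the oxygen. Both are large, so a large fall in this assay is expected for compound 4, landing near the level of compound 1. Compound 4 is therefore estimated at 15%, with a range from 0% to 35%. The expected step is a number 48 percentage points lower from compound 3 to compound 4 (beyond the scatter).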

Compound 4, a percentage reported as inhibition, at one concentration (the size of the read-out at that concentration, not a potency): 79.2%
The estimate for compound 4 lay 64.2 percentage points below the measured number; measured number above the stated range.
By their numbers in this assay, from the lowest: compound 1; then compound 2; then compound 3; then compound 4.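

In this assay, putting methyl in place of trichloromethyl gives a number 16.2 percentage points higher from compound 3 to compound 4 (beyond the scatter), so trichloromethyl is not required for a high number at this position, and the gain it brought over pentyl does not set the ceiling here. Shortening the chain matters as well: hydrogen in place of propyl gives a number 66.6 percentage points higher from compound 1 to compound 4 (beyond the scatter), and hydrogen in place of (isopropylcarbonyl)oxy gives a number 53.4 percentage points higher from compound 2 to compound 4 (beyond the scatter), which places ethyl above all three other groups on this oxygen. Nothing shown explains why the smaller ethoxycarbonyl group gives the highest number.

On these data alone, whether the number would hold or fall with methoxycarbonyl, propoxycarbonyl or (2,2,2-trifluoroethoxy)carbonyl in place of ethoxycarbonyl remains open. With one tested concentration per compound, the relative potencies of these compounds also remain open.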